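The compounds below may be only part of what the source reports. "The series", "measured", "known", "first", "only" and "open" are said of these compounds alone.

Two compounds have so far been run in a functional assay on MGC-803 cells (Homo sapiens) for cytotoxicity, read by MTT assay, with a stated time of 72 h; on this read-out higher numbers stand for weaker inhibition and lower numbers for stronger inhibition. Compound 1 `NC(=O)N1CCN(C(=S)SCc2cn(Cc3ccccc3F)nn2)CC1` gives 11300 nM, and compound 2 `NC(=O)N1CCN(C(=S)SCc2cn(Cc3ccc(F)cc3)nn2)CC1` gives 9330 nM. For the measured compounds named here, the single measured step, a 1.2-fold lower number from compound 1 to compound 2 (0.08 log units; within the scatter), moves a fluorine from one position of the benzyl ring to another, and the two numbers sit within the scatter of each other, so neither compound separates from the other on this read-out.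

Compound 3 `NC(=O)N1CCN(C(=S)SCc2cn(Cc3ccc(Cl)cc3)nn2)CC1` differs from compound 2 in one place: chloro in place of fluoro on an aromatic carbon. Going by the values given here, no measured step exchanges one halogen for another on this ring, so nothing directly bears on the change; the only step in hand shows a benzyl-ring change leaving this assay essentially unmoved. On that basis the step expected from compound 2 to compound 3, a 1.3-fold lower number from compound 2 to compound 3 (0.12 log units; within the scatter), is small and within the scatter. Compound 3 is therefore estimated at 7000 nM, with a range from 2500 nM to 20000 nM.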

Compound 3, half-maximal inhibitory concentration: > 128000 nM
Compound 3: only a limit was reported (the forecaster's own chance of this, stated with the estimate: 5%); middle value at least 18-fold (1.26 log units) away from the limit.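

In this assay, chloro in place of fluoro on the benzyl ring gives an at least 13-fold higher number from compound 2 to compound 3 (1.13 log units; beyond the scatter), and 4-chlorophenyl in place of 2-fluorophenyl gives an at least 11-fold higher number from compound 1 to compound 3 (1.05 log units; beyond the scatter). This ring carbon, para to a large group, therefore responds strongly to which halogen it carries, something that moving fluorine alone around the ring did not reveal. The value of compound 3 is a limit and not a number, so the full size of both steps stays open: the limit of > 128000 nM in this assay, at which 1 of the 3 values shown sits.

As far as these compounds go, whether this loss of inhibition belongs to chloro alone or extends to other groups on the same ring carbon, such as bromo, methyl or methoxy, remains open. Also open, from the compounds shown here alone, is how an unsubstituted benzyl group, with hydrogen in place of the halogen, would read.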